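This account rests on a few compounds, and the source may have more. Where it says the series, first, only, none or still open, it means among the compounds named here.

Three close analogues sharing one core have been run in a functional assay on MGC-803 cells (Homo sapiens) for antiproliferative activity, read by MTT assay, with a stated time of 48 h; on this read-out lower numbers stand for stronger inhibition and higher numbers for weaker inhibition. Compound 1 `O=C(Nc1ccccc1)Nc1cccc(CNc2nccnc2Cl)c1` gives 16300 nM, compound 2 `COc1ccc(NC(=O)Nc2cccc(CNc3nccnc3Cl)c2)cc1` gives 9240 nM, and compound 3 `O=C(Nc1ccc(Cl)cc1)Nc1cccc(CNc2nccnc2Cl)c1` gives 4980 nM, the lowest of the three numbers. Putting chloro in place of hydrogen on an aromatic carbon brings a 3.3-fold lower number from compound 1 to compound 3 (0.51 log units; beyond the scatter), whereas methoxy in place of hydrogen brings only a 1.8-fold lower number from compound 1 to compound 2 (0.25 log units; within the scatter), and between the two substituted compounds there is a 1.9-fold lower number from compound 2 to compound 3 (0.27 log units; within the scatter).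

Compound 4 `Cc1cccc(NC(=O)Nc2cccc(CNc3nccnc3Cl)c2)c1` has not yet been measured. It differs from compound 3 by 3-methylphenyl in place of 4-chlorophenyl on an amide-type nitrogen. Going by the values given here, no measured step introduces a methyl group and none tests a 3-methylphenyl, so the only guide is that compound 3, carrying the chloro, gave the lowest number while compound 1, with the plain phenyl, gave the highest. Compound 4 is therefore expected to land between those two, a step of a 1.8-fold higher number from compound 3 to compound 4 (0.26 log units; within the scatter) in this assay. For compound 4 the estimate is 9000 nM, within a range from 4000 nM to 20000 nM.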

Compound 4, half-maximal inhibitory concentration: 14600 nM
Compound 4: middle estimate off by 1.6-fold (0.21 log units), on the low side; the measured number falls inside the stated range.
By their numbers in this assay, from the lowest: compounds 3, 2, 4 and 1 (each within the scatter of the next, the first and the last beyond it).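

In this assay, 3-methylphenyl in place of 4-chlorophenyl on the amide-type nitrogen does not keep the number of compound 3 (a 2.9-fold higher number from compound 3 to compound 4 (0.47 log units; beyond the scatter)), so a substituted phenyl at this position does not by itself reproduce what the 4-chlorophenyl gives. The 3-methylphenyl leaves the number within the scatter of the plain phenyl (a 1.1-fold lower number from compound 1 to compound 4 (0.05 log units; within the scatter)) and of the 4-methoxyphenyl (a 1.6-fold higher number from compound 2 to compound 4 (0.20 log units; within the scatter)), which leaves compound 3 as the only one of the three substituted compounds beyond the scatter of compound 1. Nothing available gives a reason for these differences.

The step from compound 3 to compound 4 changes both the group and its place on the ring, and these compounds do not separate the two. Going by these compounds, how a fluoro, a trifluoromethyl or an amine on this phenyl would read also remains open.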